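Compound 3 and a swap on its chain

The source may hold more compounds than are shown below. What is called first, only, known or untested is meant among the compounds shown, and "the series" means these compounds.

Values below all come from a functional assay on B16 cells (Mus musculus) for cytotoxicity, read by MTT assay, with a stated time of 48 h (on this read-out lower numbers stand for stronger inhibition and higher numbers for weaker inhibition), throughout.
- compound 1 `CCOC(=O)Cn1cc(C(=O)Nc2cccc(-c3cn(CCOC(C)=O)nn3)c2)nn1` gives > 100000 nM as a limit, not a number
- compound 2 `CC(=O)OCCn1cc(C(=O)Nc2cccc(-c3cn(Cc4ccccc4)nn3)c2)nn1` gives > 100000 nM as a limit, not a number
- compound 3 `CCOC(=O)Cn1cc(-c2cccc(NC(=O)c3cn(CCOC(C)=O)nn3)c2)nn1` gives 63000 nM as a true number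

Among the measured compounds shown here, compound 3 is the only compound here with a true number. The other two rest on the limit of > 100000 nM in this assay, at which 2 of the 3 values shown sit, and no more.

Compound 4 `CC(=O)OCCn1cc(C(=O)Nc2cccc(-c3cn(CCOC(C)=O)nn3)c2)nn1` has the same atoms as compound 3, joined differently acetoxymethyl in place of ethoxycarbonyl on a saturated chain carbon bound to an aromatic nitrogen and so carries acetoxymethyl in place of ethoxycarbonyl on a saturated chain carbon bound to an aromatic nitrogen.

For the measured compounds named here, one measured step touches that place, namely an at least 1.5-fold lower number from compound 2 to compound 3 (0.20 log units; that floor lies within the scatter) and it gives no sign of a large effect. The expected result is a 1.3-fold higher number from compound 3 to compound 4 (0.10 log units; within the scatter) and so no shift beyond the scatter is expected in this assay here. For compound 4 the estimated value is 80000 nM with an expected range from 35000 nM to 180000 nM as the likely span.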

Compound 4, half-maximal inhibitory concentration: > 100000 nM
Compound 4 was reported as a limit (the forecaster's own chance of this, stated with the estimate: 45%); at least 1.2-fold (0.09 log units) between middle value and limit.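

In this assay, acetoxymethyl in place of ethoxycarbonyl on a saturated chain carbon bound to an aromatic nitrogen gives an at least 1.5-fold higher number from compound 3 to compound 4 (0.20 log units; that floor lies within the scatter), so this swap of same-sized groups shows no shift beyond the scatter, although its true size stays hidden. The steps from compound 1 and from compound 2 to compound 4 cannot be read. The series now offers few numbers to compare: the limit of > 100000 nM in this assay, at which 3 of the 4 values shown sit.

On these data alone, what a carboxylic acid or an amine would give at this place remains open. So does the true value of compound 4, which is known only as a limit.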